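The source may report more compounds than this note shows. Statements on the series, on what has been measured and on what is new or still open speak of the compounds shown alone.

In a functional assay on MCF7 cells (Homo sapiens) for inhibition, read by CCK-8 assay, with a stated time of 48 h (on this read-out higher numbers stand for weaker inhibition and lower numbers for stronger inhibition), the measured compounds read:

- compound 1 `COc1cc(-c2ccnc3cc(-c4ccc(C)cc4)nn23)cc(OC)c1OC` gives 47 nM
- compound 2 `COc1cc(-c2ccnc3cc(-c4ccc(C(C)=O)cc4)nn23)cc(OC)c1OC` gives 5230 nM
- compound 3 `COc1cc(-c2ccnc3cc(-c4ccc5cnn(C)c5c4)nn23)cc(OC)c1OC` gives 279 nM

Compound 3 holds the middle place of the three, as a 5.9-fold higher number from compound 1 to compound 3 (0.77 log units; beyond the scatter) and a 19-fold lower number from compound 2 to compound 3 (1.27 log units; beyond the scatter) show. Compound 4 `COc1ccc(-c2cc3nccc(-c4cc(OC)c(OC)c(OC)c4)n3n2)cc1N` is still unmeasured and changes one group: 3-amino-4-methoxyphenyl in place of 1-methyl-1H-indazol-6-yl on an aromatic carbon. For the measured compounds named here, no measured step makes this exact swap. The closest guides are the other two compounds with a single six-membered ring at that place, and these differ widely: a 110-fold higher number from compound 1 to compound 2 (2.05 log units; beyond the scatter). Compound 4 carries no acetyl, so the expectation leans toward compound 1 (47 nM). The expected change is a 7.0-fold lower number from compound 3 to compound 4 (0.84 log units; beyond the scatter), a modest step to a lower number in this assay. Compound 4 is estimated at 40 nM, with an expected range from 8 nM to 250 nM.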

Compound 4, half-maximal inhibitory concentration: 27 nM
Compound 4: the middle estimate sits 1.5-fold (0.17 log units) above what was measured; the measured number falls inside the stated range.
By their numbers in this assay, from the lowest: compounds 4 and 1 (each within the scatter of the next); then compound 3; then compound 2.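

In this assay, a phenyl ring at this place can carry an amino and a methoxy group and still read like the 4-methylphenyl ring: a 1.7-fold lower number from compound 1 to compound 4 (0.24 log units; within the scatter). The same change sets it far from the other two, with a 10-fold lower number from compound 3 to compound 4 (1.01 log units; beyond the scatter) and a 190-fold lower number from compound 2 to compound 4 (2.29 log units; beyond the scatter), so among these compounds the groups on this ring decide much of the result. Nothing available explains these differences. The compounds shown leave open what the amine and the methoxy each contribute alone, and how a hydroxyl or carboxylic acid in the amine's place would read.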